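A few compounds are considered here, and "the series" means these few. Any claim that something is new, unique, unknown or untested is made for them only; others in the source may bear on it.

Measured compounds:
compound 1, `CO[C@H]1CC[C@@H](Nc2cc(NCc3cnccc3C(F)(F)F)ncc2C#N)CC1`: 5000 nM
compound 2, `CO[C@H]1CC[C@@H](CNc2cc(NCc3cnccc3C(F)(F)F)ncc2C#N)CC1`: 5000 nM

In an assay on isolated protein for inhibition of protein kinase C delta type (Homo sapiens), read by TR-FRET, with a stated time of 2 h (a lower number here means a stronger inhibitor, a higher number a weaker inhibitor), compound 1 gives 5000 nM and compound 2 gives 5000 nM. Within the data shown here, the one step available, no change at the digits printed from compound 1 to compound 2 (within the scatter), shows the change from 4-methoxycyclohexyl to (4-methoxycyclohexyl)methyl on a nitrogen on an aromatic ring leaves the read-out where it was, so compound 2 stands level with compound 1 and the two numbers cannot be ordered.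

Compound 3, `N#Cc1cnc(NCc2cnccc2C(F)(F)F)cc1NCCC1CCOCC1`, keeps the shared core and differs from compound 2 at one place:
(oxan-4-yl)methyl in place of 4-methoxycyclohexyl on a saturated chain carbon bound to a nitrogen on an aromatic ring

Among the measured compounds shown here, no measured step exchanges one saturated ring for another; the step from compound 1 to compound 2 only lengthens the link and bears on the present change merely by showing that this part of the molecule has so far been tolerant of alteration. Nothing in the two values argues for a move in either direction beyond the scatter, so the expected step of no change at the digits printed from compound 2 to compound 3 (within the scatter) is essentially flat. Compound 3 is therefore estimated at 5000 nM, with a range of 2000 nM to 15000 nM, the width reflecting the absence of any directly comparable step.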

Compound 3, half-maximal inhibitory concentration: > 10000 nM
Compound 3: no number, only a limit; the forecaster's own chance of this, stated with the estimate: 35%; at least 2.0-fold (0.30 log units) between middle value and limit.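

In this assay compound 3 gives > 10000 nM, and this is a limit of the assay, not a number. The steps of an at least 2.0-fold higher number from compound 2 to compound 3 (0.30 log units; that floor lies within the scatter) and an at least 2.0-fold higher number from compound 1 to compound 3 (0.30 log units; that floor lies within the scatter) are floors only, so 2-(oxan-4-yl)ethyl on a nitrogen on an aromatic ring is not shown to differ beyond the scatter from either 4-methoxycyclohexyl or (4-methoxycyclohexyl)methyl. Unlike the step between the two earlier compounds, however, these steps have no upper bound, so this position can no longer be read as flat at the digits printed, and the change to 2-(oxan-4-yl)ethyl gives the only reading at the limit: the limit of > 10000 nM in this assay, at which 1 of the 3 values shown sits.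

The compounds shown leave open how far compound 3 actually lies from compound 1 and compound 2, and whether the exchange of the carbon-only ring for the ring with a hetero atom or the different chain carries the step, as the two are not separated here. Also open, from the compounds shown here alone, is how this position would read with an amine or a carboxylic acid on the saturated ring in place of the methoxy group.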